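Replacing the Acid-Bearing Side Chain with an Ether Chain

A few compounds are considered here, and "the series" means these few. Any claim that something is new, unique, unknown or untested is made for them only; others in the source may bear on it.

Compound 1 `O=C(O)CCC/C=C\CC1=CCC[C@@H]1NS(=O)(=O)c1ccccc1` gives 2300 nM in a functional assay on a cell-free system (plasma) for inhibition of thromboxane A2 receptor (Homo sapiens), read by turbidimetry; on this read-out lower numbers stand for stronger inhibition and higher numbers for weaker inhibition.
Compound 2 `O=C(O)CCC/C=C\CC1=CCC[C@@H]1NS(=O)(=O)c1ccc(F)cc1` gives 4400 nM; 4400 nM (2 entries) in this assay, recorded as two entries.

For the measured compounds named here, compound 1 is the only compound with a single number in this assay; compound 2 has two entries that agree with each other. The values of compound 1 and compound 2 lie close to one another, within the usual scatter of this kind of measurement, so no order between them can be claimed. Compound 3 `O=C(O)COCCCCC1=CCC[C@@H]1NS(=O)(=O)c1ccccc1` has not yet been measured. Compared with compound 1 it carries 3-(carboxymethoxy)propyl in place of 5-carboxypent-1-en-1-yl on a saturated chain carbon bound to a double-bonded ring carbon. Going by the values given here, no measured pair shows what such a change does here. The step from compound 1 to compound 3 in this assay is therefore expected to be small, at most a slight loss that may sit within the scatter, and the expected step is a 1.3-fold higher number from compound 1 to compound 3 (0.12 log units; within the scatter). For compound 3 the estimated value in this assay is 3000 nM, with a range from 800 nM to 12000 nM.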

Compound 3, half-maximal inhibitory concentration: 2000 nM
For compound 3 the middle estimate is 1.5-fold (0.18 log units) above the measured one, within the range that was stated.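

Putting 3-(carboxymethoxy)propyl in place of 5-carboxypent-1-en-1-yl, on a saturated chain carbon bound to a double-bonded ring carbon, gives a 1.2-fold lower number from compound 1 to compound 3 (0.06 log units; within the scatter) in this assay, so the two compounds cannot be told apart. At this position, then, a chain of 6 carbon and 2 oxygen atoms with its alkene can give way to one of 5 carbon and 3 oxygen atoms without a change beyond the scatter, with both chains ending in a carboxylic acid. No measurement shown here speaks to why the two chains read alike.

From the compounds shown here alone, the ether oxygen and the missing chain double bond come together in this single swap, so their separate contributions stay unknown. Going by these compounds, how a longer ether chain, or a tetrazole in place of the carboxylic acid, would read also remains open.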